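Replacing cyclopropyl with dimethylamino on the sulfonyl group

This account rests on a few compounds, and the source may have more. Where it says the series, first, only, none or still open, it means among the compounds named here.

Measured so far:
Compound 1, `Cc1ccc2[nH]c(C(=O)N[C@H]3CN(S(=O)(=O)c4cnccn4)C[C@@H]3C(=O)NCCN(C)C)cc2c1`, gives 92% in a functional assay on HEK293 cells for agonist activity at growth hormone secretagogue receptor type 1 (Homo sapiens), read by HTRF and inositol phosphate accumulation, with a stated time of 90 min, in the presence of a further agent that is not named here; on this read-out higher numbers stand for larger maximal responses and lower numbers for smaller maximal responses.
Compound 2, `Cc1ccc2[nH]c(C(=O)N[C@H]3CN(S(=O)(=O)C4CCOCC4)C[C@@H]3C(=O)NCCN(C)C)cc2c1`, gives 90% in this assay.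
Compound 3, `Cc1ccc2[nH]c(C(=O)N[C@H]3CCN(S(=O)(=O)C4CC4)C[C@@H]3C(=O)NCCN(C)C)cc2c1`, gives 95% in this assay.

Compound 3 shows the highest of the three numbers, yet its gaps to compound 1 and compound 2 both lie within the scatter, so the three compounds behave alike. Compound 4, `Cc1ccc2[nH]c(C(=O)N[C@H]3CCN(S(=O)(=O)N(C)C)C[C@@H]3C(=O)NCCN(C)C)cc2c1`, differs from compound 3 by dimethylamino in place of cyclopropyl on a sulfonyl sulfur. Among the measured compounds shown here, the one measured step at the same place, a number 2 percentage points lower from compound 1 to compound 2 (within the scatter), stayed within the scatter. On that basis no step beyond the scatter is expected in this assay, and the expected change is a number 2 percentage points lower from compound 3 to compound 4 (within the scatter). Compound 4 is therefore estimated at 93%, with a range from 84% to 100%.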

Compound 4, largest response reached (Emax), in percent of the reference or control that the assay uses: 100%
The estimate for compound 4 lay 7 percentage points below the measured number; the measured number falls inside the stated range.
By their numbers in this assay, from the lowest: compounds 2, 1, 3 and 4 (each within the scatter of the next).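

Putting dimethylamino in place of cyclopropyl in this assay gives a number 5 percentage points higher from compound 3 to compound 4 (within the scatter) and so leaves the maximal response unchanged within the scatter. All the earlier groups on this sulfonyl sulfur carried a ring, whereas dimethylamino has none and is joined through nitrogen, so a ring on the sulfur is not needed to keep this response. No supporting evidence bears on this result.

Going by these compounds, whether a larger open group such as diethylamino would also keep the response remains open. The same holds for a free amino group on the sulfur.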